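Trimming the Methoxy Group: What to Expect of Compound 4

This account rests on a few compounds, and the source may have more. Where it says the series, first, only, none or still open, it means among the compounds named here.

Measured so far in a functional assay on PC-3 cells (Homo sapiens) for cytotoxicity, read by MTT assay, with a stated time of 72 h; on this read-out higher numbers stand for weaker inhibition and lower numbers for stronger inhibition:
compound 1 `COc1ccc(-n2ccc(=O)c(C(=O)Nc3ccc(Oc4ccnc5[nH]ccc45)cc3)n2)cc1` gives > 60000 nM
compound 2 `O=C(Nc1ccc(Oc2ccnc3[nH]ccc23)cc1)c1nn(-c2ccc(Cl)c(F)c2)ccc1=O` gives 7780 nM
compound 3 `COc1ccc(-n2ccc(=O)c(C(=O)Nc3ccc(Oc4ccnc5[nH]ccc45)c(F)c3)n2)cc1` gives 46400 nM

The value of compound 1 in this assay is a limit, not a number. Of the two numbers, compound 3 holds the higher one; compound 2 sits below it, beyond the scatter. Compound 4 `O=C(Nc1ccc(Oc2ccnc3[nH]ccc23)c(F)c1)c1nn(-c2ccccc2)ccc1=O` differs from compound 3 by hydrogen in place of methoxy on an aromatic carbon. Going by the values given here, two measured steps bear on this. Swapping the aryl group on the aromatic nitrogen gave an at least 7.7-fold lower number from compound 1 to compound 2 (0.88 log units; beyond the scatter), whereas fluoro in place of hydrogen on an aromatic carbon gave an at least 1.2-fold lower number from compound 1 to compound 3 (0.11 log units; that floor lies within the scatter). Removing the methoxy from that same aryl ring is therefore expected to lower the number modestly, by a 1.9-fold lower number from compound 3 to compound 4 (0.27 log units; within the scatter). Compound 4 is expected to give 25000 nM, within 8000 nM to 60000 nM.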

Compound 4, half-maximal inhibitory concentration: 38600 nM
For compound 4 the middle estimate is 1.5-fold (0.19 log units) below the measured one, and the stated range covers the measured number.
By their numbers in this assay, from the lowest: compound 2; then compounds 4 and 3 (each within the scatter of the next). At a limit, above all of these: compound 1.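

Taking the methoxy away, 4-methoxyphenyl to phenyl, gives a 1.2-fold lower number from compound 3 to compound 4 (0.08 log units; within the scatter) in this assay, so compound 3 and compound 4 cannot be told apart. The methoxy alone therefore shows no readable effect at this place on the ring, unlike the swap to the 4-chloro-3-fluorophenyl group of compound 2. Compound 1 stands at a limit of the read-out, not at a number: the limit of > 60000 nM in this assay, at which 1 of the 4 values shown sits.

Still open, from the compounds shown here alone, is whether the chlorine or the fluorine of compound 2 carries its step. Also open, going by these compounds, is whether an amine or a carboxylic acid at this place would read differently from hydrogen.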